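A few compounds are considered here, and "the series" means these few. Any claim that something is new, unique, unknown or untested is made for them only; others in the source may bear on it.

Of the compounds shown here, three have been measured so far. Compound 1, `CC(C)(C)C(NC(=O)c1ccc(Cl)cc1)N/C(S)=N/c1cccnc1`, gives 2510 nM in a functional assay with sulfonylurea receptor 2, Kir6.2 (Homo sapiens) as the target; a lower number here means that less compound is needed, a higher number that more compound is needed for the effect. Compound 2, `CC(C)(C)C(NC(=O)c1ccc(Cl)cc1)N/C(=N/c1cccnc1)NC#N`, gives 6310 nM. The move was a 2.5-fold higher number from compound 1 to compound 2 (0.40 log units; beyond the scatter). Compound 3, `CCC(CC)(CCC#N)C(NC(=O)c1ccc(Cl)cc1)N/C(=N/c1cccnc1)NC#N`, gives 5010 nM; that change was a 1.3-fold lower number from compound 2 to compound 3 (0.10 log units; within the scatter). Among the three numbers, compound 3 stands second highest: its nearest neighbour is compound 2, within the usual scatter, and its furthest is compound 1, also within the scatter, so none of these three can be called stronger or weaker than another with confidence.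

Compound 4, `C=CC(C)(C)CC(NC(=O)c1ccc(Cl)cc1)N/C(=N/c1cccnc1)NC#N`, differs from compound 3 by 2,2-dimethylbut-3-en-1-yl in place of 1-(2-cyanoethyl)-1-ethylpropyl on a saturated chain carbon bound to an amide-type nitrogen and an amine nitrogen. Within the data shown here, the one measured step at this same place, a 1.3-fold lower number from compound 2 to compound 3 (0.10 log units; within the scatter), stayed within the scatter, while the step from compound 1 to compound 2 concerns another part of the molecule and does not bear on this change. On that basis the expected step is a 1.0-fold lower number from compound 3 to compound 4 (0.00 log units; within the scatter), with no change beyond the scatter. Compound 4 is therefore estimated at 5000 nM, with a likely range from 2000 nM to 12500 nM.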

Compound 4, half-maximal effective concentration: 10000 nM
Compound 4: the middle estimate sits 2.0-fold (0.30 log units) below what was measured, within the range that was stated.
By their numbers in this assay, from the lowest: compounds 1, 3, 2 and 4 (each within the scatter of the next, the first and the last beyond it).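

At this place, on a saturated chain carbon bound to an amide-type nitrogen and an amine nitrogen, the group can now be compared across three versions, and the third version carries a double bond instead of a nitrile. In this assay the exchange gives a 2.0-fold higher number from compound 3 to compound 4 (0.30 log units; within the scatter) and, against the smaller tert-butyl, a 1.6-fold higher number from compound 2 to compound 4 (0.20 log units; within the scatter); so neither going from 9 heavy atoms to 6 nor replacing tert-butyl with this longer chain separates these compounds. No supporting measurement is available to explain these numbers.

Going by these compounds, it remains open whether a group of another kind at this place, such as a cyclohexyl ring, an amine or a carboxylic acid, would move the number beyond the scatter. Also open, on these data alone, is how 2,2-dimethylbut-3-en-1-yl would behave with the sulfanyl group of compound 1 in place of cyanoamino.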